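Sulfur for Selenium on Two Cores: an Expected Step

A few compounds are considered here, and "the series" means these few. Any claim that something is new, unique, unknown or untested is made for them only; others in the source may bear on it.

Measured so far in an ADME assay on MCF-10A cells (Homo sapiens) for cytotoxicity, read by MTT assay, with a stated time of 72 h; on this read-out lower numbers stand for stronger inhibition of growth and higher numbers for weaker inhibition of growth:
compound 1, `C[Se]/C(=N\C(=O)c1cc2ccccc2s1)NC(=O)c1cc2ccccc2s1`, gives 490 nM;
compound 2, `C[Se]/C(=N\C(=O)c1ccco1)NC(=O)c1ccco1`, gives 5940 nM;
compound 3, `CS/C(=N\C(=O)c1cc2ccccc2s1)NC(=O)c1cc2ccccc2s1`, gives 20 nM.

Compound 3 differs from compound 1 by a group of 2 heavy atoms (1 carbon, 1 sulfur; no ring) in place of a group of 2 heavy atoms (1 carbon, 1 selenium; no ring), on a carbon with a double bond to nitrogen, and this change gave a 25-fold lower number from compound 1 to compound 3 (1.39 log units; beyond the scatter). Compound 4, `CS/C(=N\C(=O)c1ccco1)NC(=O)c1ccco1`, has not yet been measured; it differs from compound 2 by a group of 2 heavy atoms (1 carbon, 1 sulfur; no ring) in place of a group of 2 heavy atoms (1 carbon, 1 selenium; no ring), on a carbon with a double bond to nitrogen, the same change carried onto the other core. How the core of compound 2 differs from the core of compound 1 is not broken down here. Among the three measured compounds, compound 2 has the highest number and compound 3 the lowest. If the change carries over, the step is expected to be a 20-fold lower number from compound 2 to compound 4 (1.30 log units; beyond the scatter), resting on the single earlier step seen in this assay; with one example only, a wide range is kept. Compound 4 is therefore expected to give about 300 nM, likely between 80 nM and 1200 nM.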

Compound 4, concentration for 50% growth inhibition: 8220 nM
For compound 4 the middle estimate is 27-fold (1.44 log units) below the measured one; the whole stated range lies below it.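

In this assay the same change on the other core gave a 1.4-fold higher number from compound 2 to compound 4 (0.14 log units; within the scatter) and so did not repeat the large earlier step. The two steps do not agree: the same change on two cores in this assay, a 25-fold lower number (1.39 log units; beyond the scatter) from compound 1 to compound 3 and a 1.4-fold higher number (0.14 log units; within the scatter) from compound 2 to compound 4, 34-fold (1.53 log units) apart, beyond the scatter of two such steps. The change therefore cannot be carried from one core to another in this series as a fixed amount, although two pairs do not show which feature of the cores sets the difference or what a third core would give.

The compounds shown leave open how an amine or a chain longer than methylsulfanyl, on a carbon with a double bond to nitrogen, would fare on either core. They also leave open whether the gap between the two steps holds in other cell lines.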